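Shortening the amide-linked chain toward compound 4

The compounds below may be only part of what the source reports. "The series", "measured", "known", "first", "only" and "open" are said of these compounds alone.

Measured compounds:
Compound 1, `CC(C)(C)OC(=O)NCC1CCCN(C(=O)CN2CN(c3ccccc3)C3(CCN(C(=O)c4ccc(C5CCCCC5)cc4)CC3)C2=O)C1`, gives 3800 nM in an assay on HEK293 cells for displacement of a labelled ligand from NPC1-like intracellular cholesterol transporter 1 (Homo sapiens); on this read-out lower numbers stand for stronger inhibition and higher numbers for weaker inhibition.
Compound 2, `CC(C)(C)OC(=O)NCCCCNC(=O)CN1CN(c2ccccc2)C2(CCN(C(=O)c3ccc(C4CCCCC4)cc3)CC2)C1=O`, gives 4600 nM in this assay.
For compound 3, `CC(C)(C)OC(=O)NCCCCNC(=O)CN1CN(c2ccccc2)C2(CCN(C(=O)c3ccc(C(C)(C)C)cc3)CC2)C1=O`, the entry in this assay reads "not determined" (no result reported), so it has no result there.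

Among the two numbers shown, compound 2 stands as the higher, but its nearest neighbour, compound 1, lies within the usual scatter of it, so the two cannot be placed in any order. Compound 3 contributes no number and so says nothing about the step to be considered here.

Compound 4, `CC(C)(C)OC(=O)NCCNC(=O)CN1CN(c2ccccc2)C2(CCN(C(=O)c3ccc(C4CCCCC4)cc3)CC2)C1=O`, differs from compound 2 in one place: (tert-butoxycarbonyl)amino in place of 2-((tert-butoxycarbonyl)amino)ethyl on a saturated chain carbon, two bonds along the chain from an amide-type nitrogen. For the measured compounds named here, no step between two measured compounds isolates a change of this kind, so nothing comparable is known. The expectation is therefore for no step beyond the scatter, with a slight lean toward a higher number: the estimated step from compound 2 to compound 4 in this assay is a 1.2-fold higher number from compound 2 to compound 4 (0.08 log units; within the scatter). Compound 4 is estimated at 5500 nM, with a range from 2000 nM to 15000 nM.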

Compound 4, half-maximal inhibitory concentration: 5500 nM
Estimate against measurement, compound 4: no gap at the digits printed; the range from low to high includes it.
By their numbers in this assay, from the lowest: compounds 1, 2 and 4 (each within the scatter of the next).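

In this assay, for the compounds shown here, the first one-place change with numbers on both sides, (tert-butoxycarbonyl)amino in place of 2-((tert-butoxycarbonyl)amino)ethyl on a saturated chain carbon, two bonds along the chain from an amide-type nitrogen, gives a 1.2-fold higher number from compound 2 to compound 4 (0.08 log units; within the scatter) and so leaves the two compounds indistinguishable. At this position, then, the read-out does not resolve the difference between these two chain lengths, at least while the tert-butoxycarbonyl group stays at the chain end. No measurement on hand bears on why this is so.

The compounds shown leave open whether a free amine or a carboxylic acid at the chain end, rather than the tert-butoxycarbonyl-protected amine, would move the number beyond the scatter. Whether a longer chain than 4-((tert-butoxycarbonyl)amino)butyl would do so also remains unanswered.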